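From oxetan-3-yl to carboxymethyl on the shared core

The compounds below may be only part of what the source reports. "The series", "measured", "known", "first", "only" and "open" are said of these compounds alone.

Measured so far in a physicochemical assay for solubility, read by chemiluminescence, measured as kinetic solubility; on this read-out lower numbers stand for lower solubility and higher numbers for higher solubility:
- compound 1 `CNC(=O)Cn1nc(OC)c2c(NS(=O)(=O)c3cccc(Cl)c3Cl)ncnc21`: >= 509000 nM, a limit of the assay
- compound 2 `COc1nn(C2COC2)c2ncnc(NS(=O)(=O)c3cccc(Cl)c3Cl)c12`: 142000 nM

For the measured compounds named here, compound 2 gives 142000 nM, the only exact number so far. Compound 1 gives >= 509000 nM, which is only a limit (the limit of >= 509000 nM in this assay, at which 1 of the 2 values shown sits).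

Compound 3 `COc1nn(CC(=O)O)c2ncnc(NS(=O)(=O)c3cccc(Cl)c3Cl)c12` keeps the shared core but carries carboxymethyl in place of oxetan-3-yl on an aromatic nitrogen. Going by the values given here, one measured step bears on this, at the same nitrogen: an at least 3.5-fold lower number from compound 1 to compound 2 (0.55 log units; beyond the scatter). There, oxetan-3-yl replaced (methylcarbamoyl)methyl. Carboxymethyl, with no ring and a double bond outside aromatic rings, resembles the open chain of compound 1 more than the ring of compound 2. A single step is thin support, but it points to a rise of similar size in this assay, beyond the scatter. The expected change is a 3.0-fold higher number from compound 2 to compound 3 (0.47 log units; beyond the scatter). The estimate for compound 3 is 420000 nM, with an expected range from 200000 nM to 600000 nM.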

Compound 3, solubility: >= 483000 nM
Compound 3: no number, only a limit; the forecaster's own chance of this, stated with the estimate: 50%; middle value at least 1.1-fold (0.06 log units) away from the limit.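

In this assay, carboxymethyl in place of oxetan-3-yl on the aromatic nitrogen gives an at least 3.4-fold higher number from compound 2 to compound 3 (0.53 log units; beyond the scatter). This adds a second open chain to the picture: compound 1 and compound 3 both carry an open chain at this nitrogen, and both read higher than compound 2 with its oxetan-3-yl ring, so the earlier drop no longer rests on one chain alone. Compound 3 gives only a limit of the assay, so the full size of this rise stays unknown: the limit of >= 483000 nM in this assay, at which 1 of the 3 values shown sits.

Compound 1 and compound 3 both stand at limits and the step between them cannot be read, which leaves hydroxy and methylamino on the carbonyl carbon unranked. Also open, on these data alone, is where a longer chain such as carboxyethyl, or an amine such as aminoethyl, would fall at this nitrogen.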